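Changing the chain end of compound 3

A few compounds are considered here, and "the series" means these few. Any claim that something is new, unique, unknown or untested is made for them only; others in the source may bear on it.

In a functional assay on MDA-MB-231 cells (Homo sapiens) for inhibition, read by MTT assay, with a stated time of 72 h (a higher number here means a weaker inhibitor, a lower number a stronger inhibitor), compound 3 (`Nc1nc2cc(-c3nn(CCCCC(=O)NO)c4ncnc(N)c34)ccc2o1`) gives 21200 nM, within the scatter of compound 1 (`Nc1ncnc2c1c(-c1cnc3[nH]ccc3c1)nn2CCCCCCCCC(=O)NO`) at 11000 nM. Compound 2 (`Nc1ncnc2c1c(-c1cnc3[nH]ccc3c1)nn2CCCCCC(=O)NO`) is reported only as a limit, > 100000 nM. Compound 4 (`CNC(=O)CCCCCCCn1nc(-c2ccc3oc(N)nc3c2)c2c(N)ncnc21`) carries 3-(methylcarbamoyl)propyl in place of hydroxycarbamoyl on a saturated chain carbon, four bonds along the chain from an aromatic nitrogen. For the measured compounds named here, the one measured step on chain length is an at least 9.0-fold higher number from compound 1 to compound 2 (0.95 log units; beyond the scatter), beyond the scatter, and it runs from longer to shorter. Going by the values given here, this hints at a lower number for the longer chain of compound 4, but no measured compound ends in methylcarbamoyl. No step beyond the scatter is expected, an estimated 1.4-fold higher number from compound 3 to compound 4 (0.15 log units; within the scatter). Compound 4 is expected at 30000 nM, with an estimated range of 8000 nM to 100000 nM.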

Compound 4, half-maximal inhibitory concentration: 2900 nM
Compound 4: middle estimate off by 10-fold (1.01 log units), on the high side; the measured number lies below the stated range.
By their numbers in this assay, from the lowest: compound 4; then compounds 1 and 3 (each within the scatter of the next). At a limit, above all of these: compound 2.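

Keeping the core of compound 3 and replacing hydroxycarbamoyl with 3-(methylcarbamoyl)propyl gives, in this assay, a 7.3-fold lower number from compound 3 to compound 4 (0.86 log units; beyond the scatter). So at this position, four bonds along the chain from an aromatic nitrogen, a chain without hydroxycarbamoyl can still give a lower number, which the earlier compounds, all ending in hydroxycarbamoyl, could not show. Nothing shown here gives a cause for this step.

The step lengthens the chain and changes its end at once, so the two effects cannot be separated. From the compounds shown here alone, how a carboxylic acid or an amine at the chain end would read stays open.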